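Removing the Methyl from the Pyrazole Nitrogen of Compound 1

This account rests on a few compounds, and the source may have more. Where it says the series, first, only, none or still open, it means among the compounds named here.

Compound 1 `Cc1ccc(OCC(=O)N(Cc2cccs2)c2ccnn2C)cc1` and compound 2 `CCN(Cc1cccs1)C(=O)COc1ccc(C(C)C)cc1` share an aryloxyacetamide arrangement carrying a thiophenylmethyl group on the amide nitrogen. In an assay on HEK293 cells for agonist activity at transient receptor potential cation channel subfamily M member 8 (Homo sapiens), read by fluorescence and calcium flux, with a stated time of 15 min (a higher number here means that more compound is needed for the effect, a lower number that less compound is needed), compound 1 gives 422 nM, the higher of the two numbers recorded so far, while compound 2 gives 397 nM; the two values lie within the scatter of each other, so they are best read as equivalent. Within the data shown here, no pair of measured compounds differs in a single place, so no measured step is available for guidance.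

Compound 3 `Cc1ccc(OCC(=O)N(Cc2cccs2)c2ccn[nH]2)cc1` has not yet been measured. It differs from compound 1 in one place: hydrogen in place of methyl on an aromatic nitrogen. Among the measured compounds shown here, with no measured step to rest on, the direction of the change in this assay cannot be read from the data, and the step from compound 1 to compound 3 is expected to be a 1.4-fold higher number from compound 1 to compound 3 (0.15 log units; within the scatter), that is, within or only modestly beyond the scatter. In this assay compound 3 is estimated at 600 nM, with a range from 200 nM to 2000 nM.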

Compound 3, half-maximal effective concentration: 0.2 nM
Beside the measured number, compound 3's estimate is 3000-fold (3.48 log units) above it; measured number outside the range, below it.
By their numbers in this assay, from the lowest: compound 3; then compounds 2 and 1 (each within the scatter of the next).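

The change from 1-methyl-1H-pyrazol-5-yl to 1H-pyrazol-5-yl gives a 2100-fold lower number from compound 1 to compound 3 (3.32 log units; beyond the scatter) in this assay. This shows something compound 1 and compound 2 could not: the aromatic nitrogen is a place where the number in this assay responds very strongly to a small change. Only a single carbon leaves and a hydrogen enters, no ring is involved and no net charge, yet the step is large, and nothing measured here accounts for its size.

The compounds shown leave open whether an ethyl group or an acetyl group on this nitrogen would give a number near that of compound 1 or near that of compound 3. As far as these compounds go, it also remains open whether the step keeps its size when other parts of the core of compound 1 are changed.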